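Series notes: one aryl swap, all values at the limit

The source may report more compounds than this note shows. Statements on the series, on what has been measured and on what is new or still open speak of the compounds shown alone.

Compound 1 `N#CC1=C(N)Oc2c(c3nc4ccccc4nc3c3ccccc23)C12C(=O)N(Cc1cnnn1-c1ccc([N+](=O)[O-])cc1)c1ccccc12` opens the first pair. In a functional assay on HepG2 cells (Homo sapiens) for antiproliferative activity, read by MTT assay, with a stated time of 48 h (a lower number here means a stronger inhibitor, a higher number a weaker inhibitor), compound 1 gives > 50000 nM, which is a limit of the assay and not a number. Compound 2 `Cc1ccc(-n2nncc2CN2C(=O)C3(C(C#N)=C(N)Oc4c3c3nc5ccccc5nc3c3ccccc43)c3ccccc32)cc1C` differs from compound 1 by 3,4-dimethylphenyl in place of 4-nitrophenyl on an aromatic nitrogen. In this assay compound 2 gives > 50000 nM, again a limit. The step that the two limits leave unreadable from compound 1 to compound 2 is therefore of unreadable size, a consequence of the limit of > 50000 nM in this assay, at which 3 of the 3 values shown sit.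

Compound 3 `N#CC1=C(N)Oc2c(N)cc3nc4ccccc4nc3c2C12C(=O)N(Cc1cnnn1-c1ccc([N+](=O)[O-])cc1)c1ccccc12` has another core; the difference between the core of compound 3 and the core of compound 1 is not broken down here. In this assay compound 3 gives > 50000 nM, once more a limit. Compound 4 `Cc1ccc(-n2nncc2CN2C(=O)C3(C(C#N)=C(N)Oc4c(N)cc5nc6ccccc6nc5c43)c3ccccc32)cc1C` is not yet measured and differs from compound 3 by 3,4-dimethylphenyl in place of 4-nitrophenyl on an aromatic nitrogen. The place of this change is the same word for word as in the first pair, so it is the same change, made twice in all among these compounds.

Compound 4 is expected to show a step that the limit leaves unreadable from compound 3 to compound 4, which is to say essentially no readable movement. This expectation rests on compound 3, which stands at > 50000 nM. It rests also on compound 2, which after the same change stands at > 50000 nM, so that the change has not been seen to give a readable number for any member of this set. For compound 4 in this assay the estimate is 70000 nM, with a range from 20000 nM to 300000 nM, and the most likely outcome is that compound 4 is again reported only as a limit.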

Compound 4, half-maximal inhibitory concentration: > 50000 nM
Compound 4: a limit, no number; the forecaster's own chance of this, stated with the estimate: 85%; the middle value lies beyond the limit too.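

In this assay compound 4 gives > 50000 nM as a limit of the assay and not a number. Compound 3 also stands only at a limit, so the step from compound 3 to compound 4 cannot be read. The compounds shown leave open whether 3,4-dimethylphenyl in place of 4-nitrophenyl changes antiproliferative activity at all, on either core.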